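This account rests on a few compounds, and the source may have more. Where it says the series, first, only, none or still open, it means among the compounds named here.

Measured so far in a functional assay on MGC-803 cells (Homo sapiens) for inhibition, read by MTT assay, with a stated time of 72 h; on this read-out lower numbers stand for stronger inhibition and higher numbers for weaker inhibition:
Compound 1 `CC(C)c1ccc(-c2nc(SCc3cn(CC(=O)NC(=O)Nc4ccccn4)nn3)nc(Nc3cccc(C(F)(F)F)c3)c2C#N)cc1` gives > 64000 nM, a limit of the assay.
Compound 2 `COc1ccc(Nc2nc(SCc3cn(CC(=O)NC(=O)Nc4ccccn4)nn3)nc(-c3ccc(C(C)C)cc3)c2C#N)cc1` gives > 64000 nM, also a limit of the assay.
Compound 3 `CC(C)c1ccc(Nc2nc(SCc3cn(CC(=O)NC(=O)Nc4ccccn4)nn3)nc(-c3ccc(C(C)C)cc3)c2C#N)cc1` gives 15800 nM.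

Within the data shown here, compound 3 thus stands as the only compound of the three with a number rather than a limit; the other two values both sit at the limit of > 64000 nM in this assay, at which 2 of the 3 values shown sit. The steps of an at least 4.0-fold lower number from compound 1 to compound 3 (0.60 log units; beyond the scatter) and an at least 4.0-fold lower number from compound 2 to compound 3 (0.60 log units; beyond the scatter) both come from a change of the group on a nitrogen on an aromatic ring, and the step that the two limits leave unreadable from compound 1 to compound 2 remains unreadable between two limits.

Compound 4 `COc1cc(-c2nc(SCc3cn(CC(=O)NC(=O)Nc4ccccn4)nn3)nc(Nc3ccc(C(C)C)cc3)c2C#N)cc(OC)c1OC` is not yet measured. It differs from compound 3 by 3,4,5-trimethoxyphenyl in place of 4-isopropylphenyl on an aromatic carbon. Among the measured compounds shown here, no measured step touches this position on an aromatic carbon. For the measured compounds named here, the only measured step involving a methoxy group is an at least 4.0-fold lower number from compound 2 to compound 3 (0.60 log units; beyond the scatter), in which isopropyl in place of methoxy, on a nitrogen on an aromatic ring, gave the lower number; the present change runs the opposite way, with three methoxy groups entering and isopropyl leaving, and if it carries over at all it points to a higher number. The step of a 2.5-fold higher number from compound 3 to compound 4 (0.40 log units; beyond the scatter) is therefore expected to run toward a higher number, possibly beyond the scatter. Compound 4 is estimated at 40000 nM, within 12000 nM to 130000 nM, with a real chance that this assay again reports only a limit.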

Compound 4, half-maximal inhibitory concentration: 35500 nM
Compound 4: the middle estimate sits 1.1-fold (0.05 log units) above what was measured, and the stated range covers the measured number.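

Among these compounds, this is the first measured change on the aromatic carbon ortho to a cyano group: in this assay, 3,4,5-trimethoxyphenyl in place of 4-isopropylphenyl gives a 2.2-fold higher number from compound 3 to compound 4 (0.35 log units; beyond the scatter), so the read-out responds to the group held here, though only modestly. Compound 4 gives 35500 nM, a number and not a limit, so this position accepts an aryl group carrying three methoxy groups, with weaker inhibition, while the value stays measurable. Compound 1 and compound 2 also hold 4-isopropylphenyl at this position but differ on the nitrogen-borne aryl group and remain limits of the assay, so the numbers in the series so far come only from compound 3 and compound 4, which share the (4-isopropylphenyl)amino group: the limit of > 64000 nM in this assay, at which 2 of the 4 values shown sit.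

The shown compounds do not separate the contributions of the three methoxy groups, so it stays open whether a single 4-methoxy group on this phenyl would give the same shift as all three together. Also open, going by these compounds, is how this position would respond to a non-aryl substituent such as a morpholine or other amine, or to a phenyl ring bearing a carboxylic acid, with the rest of the shared core held constant.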